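Sulfonamide amide series: replacing the pyrrolidine with isopropyl

This account rests on a few compounds, and the source may have more. Where it says the series, first, only, none or still open, it means among the compounds named here.

Measured so far:
compound 1, `CC(C)N1CC[C@H](NC(=O)c2cc(-c3ccc(NS(=O)(=O)c4cccc(Cl)c4Cl)cc3)nc3[nH]ncc23)C1`, in an assay for inhibition of serine/threonine-protein kinase Sgk1 (Homo sapiens), with stated times of 30 min and 60 min, in the presence of a further agent that is not named here (a higher number here means a weaker inhibitor, a lower number a stronger inhibitor), gives 38 nM
compound 2, `O=C(NC1CCN(CC2CC2)C1)c1cc(-c2ccc(NS(=O)(=O)c3cccc(Cl)c3Cl)cc2)nc2[nH]ncc12`, in this assay gives 35 nM

Compound 2 holds the lowest of the two numbers in this assay, with compound 1 nearest; the step of a 1.1-fold lower number from compound 1 to compound 2 (0.04 log units; within the scatter) is within the scatter, so the two are not distinguished.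

The next compound, compound 3, `CC(C)NC(=O)c1cc(-c2ccc(NS(=O)(=O)c3cccc(Cl)c3Cl)cc2)nc2[nH]ncc12`, differs from compound 2 in one place: isopropyl in place of 1-(cyclopropylmethyl)pyrrolidin-3-yl on an amide-type nitrogen.

Going by the values given here, the only measured step, a 1.1-fold lower number from compound 1 to compound 2 (0.04 log units; within the scatter), exchanges one group for another on the pyrrolidine nitrogen and leaves the ring itself in place. It shows that the group on that nitrogen may be varied without a step beyond the scatter, but it says nothing about taking the whole pyrrolidine away, which is what happens from compound 2 to compound 3. Among the compounds with values here, there is no measured precedent for this change in the set. A step beyond the scatter toward a higher number is held as the more likely outcome, with wide uncertainty.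

Compound 3 is therefore estimated at 110 nM in this assay, within 35 nM to 350 nM, meaning an expected step of a 3.1-fold higher number from compound 2 to compound 3 (0.50 log units; beyond the scatter).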

Compound 3, half-maximal inhibitory concentration: 17600 nM
The estimate for compound 3 lay 160-fold (2.20 log units) below the measured number; the whole stated range lies below it.
By their numbers in this assay, from the lowest: compounds 2 and 1 (each within the scatter of the next); then compound 3.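

In this assay, the group on the amide-type nitrogen turns out to matter greatly: the data show a 500-fold higher number from compound 2 to compound 3 (2.70 log units; beyond the scatter) and also a 460-fold higher number from compound 1 to compound 3 (2.67 log units; beyond the scatter) when isopropyl takes the place of the substituted pyrrolidine. Both steps are large, whereas the exchange on the pyrrolidine nitrogen alone stayed within the scatter, so that nitrogen's substituent can vary among the groups shown, but the whole 1-substituted pyrrolidin-3-yl cannot be traded for isopropyl without a heavy loss of inhibition in this series. No supporting measurement is available to account for this loss.

Isopropyl differs from the departing groups in lacking both the ring and its nitrogen, so the compounds shown do not tell which of these features, or the overall size of the group, carries the effect. On these data alone, it remains open whether a cyclopentyl group, which keeps a ring without the nitrogen, or an open-chain amine such as 2-(dimethylamino)ethyl, which keeps the nitrogen without the ring, would stand nearer to compound 2 or to compound 3.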